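A few compounds are considered here, and "the series" means these few. Any claim that something is new, unique, unknown or untested is made for them only; others in the source may bear on it.

In a physicochemical assay for lipophilicity, using the shake flask method, measured as octanol-water partition, at pH 7.4 (on this read-out higher numbers stand for higher lipophilicity and lower numbers for lower lipophilicity), compound 1 `CC(=O)N[C@@H]1CCC[C@H](C(=O)Nc2cc(-c3cnn4c3CCCC4)c(Cl)cn2)C1` gives 3.2 and compound 2 `CC(=O)N[C@@H]1CCC[C@H](C(=O)Nc2cc(-c3cnc4n3CCCC4)c(Cl)cn2)C1` gives 2.7 while compound 3 `CC(=O)N[C@@H]1CCC[C@H](C(=O)Nc2cc(-c3cnc(C)n3C)c(Cl)cn2)C1` gives 2.2 as the lowest of the three. Compound 4 `CC(=O)N[C@@H]1CCC[C@H](C(=O)Nc2cc(-c3nnn4ccccc34)c(Cl)cn2)C1` is still unmeasured and differs from compound 3 on an aromatic carbon ortho to a chloro group (a group of 9 heavy atoms (6 carbon, 3 nitrogen; one five-membered aromatic ring with 3 hetero atoms, one six-membered aromatic ring with 1 hetero atom) in place of a group of 7 heavy atoms (5 carbon, 2 nitrogen; one five-membered aromatic ring with 2 hetero atoms), on an aromatic carbon). Two modest steps bear on this, a number 1.00 log units lower from compound 1 to compound 3 (beyond the scatter) and also a number 0.50 log units lower from compound 2 to compound 3 (beyond the scatter) as a group with a six-membered non-aromatic ring gives way to the 1,2-dimethyl-1H-imidazol-5-yl group. Among the measured compounds shown here, compound 4 reverses that kind of swap, although its six-membered ring is aromatic and no measured step covers this. In this assay a modest rise is expected, with the estimated change being a number 0.60 log units higher from compound 3 to compound 4 (beyond the scatter) (in the same direction as the reversed steps). Compound 4 is estimated at 2.8 (expected range 2.3 to 3.3).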

Compound 4, distribution coefficient: 2
Estimate against measurement, compound 4: 0.80 log units above; measured number below the stated range.
By their numbers in this assay, from the lowest: compounds 4 and 3 (each within the scatter of the next); then compound 2; then compound 1.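

In this assay, the fused group of compound 4 at this place does not follow the two groups with a six-membered non-aromatic ring: replacing the 1,2-dimethyl-1H-imidazol-5-yl group gives a number 0.20 log units lower from compound 3 to compound 4 (within the scatter) and no rise. Against those two groups the steps are a number 0.70 log units lower from compound 2 to compound 4 (beyond the scatter) and a number 1.20 log units lower from compound 1 to compound 4 (beyond the scatter) even though all three groups hold the same number of heavy atoms. Among these four compounds, a six-membered ring in the group goes with the higher numbers only in its non-aromatic form, in compound 1 and compound 2.

On these data alone, whether a simple phenyl or a morpholine at this place would fall in with these numbers stays open. Nothing measured here accounts for the result.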